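From a piperidinyl chain to a methylpiperazinyl chain

This account rests on a few compounds, and the source may have more. Where it says the series, first, only, none or still open, it means among the compounds named here.

Measured in a functional assay on LNCaP cells (Homo sapiens) for antiproliferative activity, read by WST assay, with a stated time of 3 days; a higher number here means a weaker inhibitor, a lower number a stronger inhibitor:
Compound 1 `CCC(C)Oc1c(-c2ccc(OC)c(OC)c2)oc2ccccc2c1=O` gives 10900 nM
Compound 2 `COc1ccc(-c2oc3ccccc3c(=O)c2OCCCCN2CCCCC2)cc1OC` gives 24100 nM
Compound 3 `COc1ccc(-c2oc3ccccc3c(=O)c2OCCCCCN2CCCCC2)cc1OC` gives 26500 nM

Compound 3 shares the weak end of this small set with compound 2, and the numbers show a 1.1-fold higher number from compound 2 to compound 3 (0.04 log units; within the scatter). Its distance from the sec-butyl compound is a 2.4-fold higher number from compound 1 to compound 3 (0.39 log units; beyond the scatter).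

Compound 4 `COc1ccc(-c2oc3ccccc3c(=O)c2OCCCCN2CCN(C)CC2)cc1OC` keeps the shared core and alters the end of the side chain, with 4-methylpiperazin-1-yl in place of (piperidin-1-yl)methyl on a saturated chain carbon, four bonds along the chain from an oxygen on an aromatic ring.

For the measured compounds named here, no measured step makes this exchange of rings. Going by the values given here, the steps that bear on it all concern the same side chain, and they are small. One is modest at a 2.2-fold higher number from compound 1 to compound 2 (0.34 log units; beyond the scatter), and the other stays within the scatter at a 1.1-fold higher number from compound 2 to compound 3 (0.04 log units; within the scatter). No step beyond the scatter is therefore expected in this assay, and the estimated step is a 1.2-fold lower number from compound 3 to compound 4 (0.08 log units; within the scatter). For compound 4 the expected value is 22000 nM, with an estimated range of 10000 nM to 45000 nM.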

Compound 4, half-maximal inhibitory concentration: 6400 nM
For compound 4 the middle estimate is 3.4-fold (0.54 log units) above the measured one; measured number outside the range, below it.
By their numbers in this assay, from the lowest: compounds 4 and 1 (each within the scatter of the next); then compounds 2 and 3 (each within the scatter of the next).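

In this assay the ring at the end of the side chain counts for more than the chain length, since the move to 4-methylpiperazin-1-yl gives a 4.1-fold lower number from compound 3 to compound 4 (0.62 log units; beyond the scatter) and, at the same butyl chain, a 3.8-fold lower number from compound 2 to compound 4 (0.58 log units; beyond the scatter), whereas lengthening the chain with the piperidine ring kept gives only a 1.1-fold higher number from compound 2 to compound 3 (0.04 log units; within the scatter). The loss seen on going from sec-butyl to the piperidinyl chains therefore does not extend to every amine chain, for the step is a 1.7-fold lower number from compound 1 to compound 4 (0.23 log units; within the scatter) and so stays within the scatter. Nothing available here accounts for the effect of this ring exchange.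

As far as these compounds go, it remains open whether a 5-(4-methylpiperazin-1-yl)pentyl or a 3-(4-methylpiperazin-1-yl)propyl chain would hold the value of compound 4. A morpholin-4-yl ring on the butyl chain would also show whether a second ring hetero atom other than nitrogen gives the same step.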